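The source may hold more compounds than are shown below. What is called first, only, known or untested is meant among the compounds shown, and "the series" means these compounds.

In an ADME assay on HepG2 cells (Homo sapiens) for cytotoxicity, read by luminescence, CellTiter-Glo and ATP content, with a stated time of 72 h (on this read-out lower numbers stand for an effect already at smaller amounts and higher numbers for an effect only at larger amounts of compound), compound 3 `COc1cccc(CNCCCNc2ccnc3cc(Cc4ccccc4)ccc23)c1O` gives 5720 nM, which places it second highest among the three measured compounds. Its nearest neighbour is compound 2 `COc1ccccc1Oc1ccc2c(NCCCNCc3cccc(OC)c3O)ccnc2c1`, which gives 11200 nM, and the pair differ by a 2.0-fold lower number from compound 2 to compound 3 (0.29 log units; within the scatter). Compound 1 `COc1cccc(CNCCCNc2ccnc3cc(C4CCCCC4)ccc23)c1O` gives 1080 nM; the shift from it to compound 3 is a 5.3-fold higher number from compound 1 to compound 3 (0.72 log units; beyond the scatter), and from it to compound 2 a 10-fold higher number from compound 1 to compound 2 (1.02 log units; beyond the scatter). All three compounds share one core and differ only in the group on the aromatic carbon of the fused system.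

Compound 4 `COc1cccc(CNCCCNc2ccnc3cc(-c4cccc5ccccc45)ccc23)c1O` continues this series with naphthalen-1-yl in place of benzyl on an aromatic carbon. For the measured compounds named here, no measured step covers a change from benzyl to naphthalen-1-yl, so the two steps out of compound 1, a 5.3-fold higher number from compound 1 to compound 3 (0.72 log units; beyond the scatter) and a 10-fold higher number from compound 1 to compound 2 (1.02 log units; beyond the scatter), are the only guide to how much this position can move the number; they show modest to large shifts. Compound 4 is therefore expected to differ from compound 3 by a modest step, a 2.3-fold lower number from compound 3 to compound 4 (0.36 log units; beyond the scatter), toward a lower number. The estimated value for compound 4 is 2500 nM, with a range from 800 nM to 8000 nM.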

Compound 4, half-maximal effective concentration: 2520 nM
Beside the measured number, compound 4's estimate is 1.0-fold (0.00 log units) below it, and the stated range covers the measured number.
By their numbers in this assay, from the lowest: compound 1; then compound 4; then compounds 3 and 2 (each within the scatter of the next).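

In this assay the change from benzyl to naphthalen-1-yl gives a 2.3-fold lower number from compound 3 to compound 4 (0.36 log units; beyond the scatter) and so, unlike the earlier exchange of 2-methoxyphenoxy for benzyl, shows that replacing one aromatic group with another at this carbon can move the number beyond the scatter. Compound 4 stands apart from both other neighbours, with a 4.4-fold lower number from compound 2 to compound 4 (0.65 log units; beyond the scatter) on one side and a 2.3-fold higher number from compound 1 to compound 4 (0.37 log units; beyond the scatter) on the other, so cyclohexyl still gives the lowest number of the series. Nothing shown gives a reason for these shifts.

Because naphthalen-1-yl differs from benzyl both in its ring system and in lacking the connecting carbon, the compounds shown cannot separate those two changes, and phenyl or naphthalen-2-yl would bear on this. Going by these compounds, how an amine or a carboxylic acid on this aromatic carbon would compare also remains open.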